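Fluoro to Methyl on the Aryl Ether and Permeability

The source may report more compounds than this note shows. Statements on the series, on what has been measured and on what is new or still open speak of the compounds shown alone.

Compound 1, `Cc1ccc(Oc2ccc3nc(COc4cccc(C(=O)O)c4)n(C)c3c2)nc1`: in an ADME assay for permeability, using PAMPA, with a stated time of 4 h (a higher number here means that the compound crosses the layer faster, a lower number that the compound crosses the layer more slowly), compound 1 gives 4.8 10^-6 cm/s
Compound 2, `Cn1c(COc2cccc(C(=O)O)c2)nc2ccc(Oc3ccc(F)cn3)cc21`: compound 2 gives 4.7 10^-6 cm/s
Compound 3, `Cn1c(COc2cccc(C(=O)O)c2)nc2ccc(Oc3ncc(Cl)cc3F)cc21`: compound 3 gives 11.8 10^-6 cm/s

The change methyl in place of fluoro on an aromatic carbon, (methyl in place of fluoro on an aromatic carbon), made a 1.0-fold higher number from compound 2 to compound 1 (0.01 log units; within the scatter). Compound 4, `Cc1cc(Cl)cnc1Oc1ccc2nc(COc3cccc(C(=O)O)c3)n(C)c2c1`, carries the same kind of change relative to compound 3, (methyl in place of fluoro on an aromatic carbon); the surroundings differ, since in compound 1 the place is two atoms from the ring nitrogen and para to a large group, whereas in compound 4 it is ortho to a large group, two atoms from the ring nitrogen and meta to a chloro group. The two cores differ by 5-chloro-3-fluoropyridin-2-yl in place of 5-fluoropyridin-2-yl on an oxygen on an aromatic ring, which made a 2.5-fold higher number from compound 2 to compound 3 (0.40 log units; beyond the scatter). The step of a 1.0-fold higher number from compound 3 to compound 4 (0.01 log units; within the scatter) is expected to be small because a 1.0-fold higher number from compound 2 to compound 1 (0.01 log units; within the scatter) lay within the scatter. Compound 4 is therefore estimated at 12 10^-6 cm/s, expected between 6 10^-6 cm/s and 24 10^-6 cm/s.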

Compound 4, apparent permeability: 13.7 10^-6 cm/s
Compound 4: the middle estimate sits 1.1-fold (0.06 log units) below what was measured, within the range that was stated.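

In this assay, methyl in place of fluoro made a 1.2-fold higher number from compound 3 to compound 4 (0.06 log units; within the scatter), and the same change on the other core agrees with it: the same change on two cores in this assay, a 1.0-fold higher number (0.01 log units; within the scatter) from compound 2 to compound 1 and a 1.2-fold higher number (0.06 log units; within the scatter) from compound 3 to compound 4, 1.1-fold (0.06 log units) apart, within the scatter of two such steps

The larger steps belong to the change of the whole group on the oxygen, with 5-chloro-3-methylpyridin-2-yl in place of 5-fluoropyridin-2-yl making a 2.9-fold higher number from compound 2 to compound 4 (0.46 log units; beyond the scatter) and in place of 5-methylpyridin-2-yl making a 2.9-fold higher number from compound 1 to compound 4 (0.46 log units; beyond the scatter). This shows the change carrying over between two cores only, and it does not show that it would do so on a core that differs elsewhere, or which part of the group accounts for the larger steps.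

Going by these compounds, whether an ethyl, a methoxy or a nitrile in the same place would behave like methyl and fluoro remains open.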